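Swapping a Thiophene Ring for a Nitrophenyl Group

The source may hold more compounds than are shown below. What is called first, only, known or untested is meant among the compounds shown, and "the series" means these compounds.

Of the compounds shown here, three sharing one core have been tested in an ADME assay on HEL cells (Homo sapiens) for cytotoxicity, with a stated time of 3 days; on this read-out higher numbers stand for lower toxicity in this test and lower numbers for higher toxicity in this test. Compound 1 `Cc1cc(-c2ccc(O)cc2)c2ncc(CSCCc3ccccc3)n2c1` gives 13.7 ug/mL. Compound 3 `Cc1cc(-c2ccccc2)c2ncc(CSCCc3ccccc3)n2c1` gives 33 ug/mL. Compound 2 `Cc1cc(-c2cccs2)cn2c(CSCCc3ccccc3)cnc12` gives 32 ug/mL, which stands second highest of the three numbers, within the scatter of compound 3 and beyond the scatter of compound 1. Going by the values given here, the only measured step that changes a single place is a 2.4-fold higher number from compound 1 to compound 3 (0.38 log units; beyond the scatter), hydrogen in place of hydroxy on an aromatic carbon.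

Compound 4 `Cc1cc(-c2cccc([N+](=O)[O-])c2)cn2c(CSCCc3ccccc3)cnc12` differs from compound 2 by 3-nitrophenyl in place of thiophen-2-yl on an aromatic carbon. Among the compounds with values here, no measured step exchanges one aryl ring for another, so the nearest guide is the pair of compound 2 and compound 3, whose values sit within the scatter of each other, while the step from compound 1 to compound 3 was modest. The number for compound 4 is therefore expected to move by a 1.1-fold lower number from compound 2 to compound 4 (0.03 log units; within the scatter), which is not beyond the scatter. Compound 4 is estimated at 30 ug/mL, with a range from 12 ug/mL to 65 ug/mL.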

Compound 4, half-maximal cytotoxic concentration: 43 ug/mL
For compound 4 the middle estimate is 1.4-fold (0.16 log units) below the measured one, within the range that was stated.
By their numbers in this assay, from the lowest: compound 1; then compounds 2, 3 and 4 (each within the scatter of the next).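

In this assay, putting 3-nitrophenyl in place of thiophen-2-yl on this aromatic carbon gives a 1.3-fold higher number from compound 2 to compound 4 (0.13 log units; within the scatter), so exchanging a five-membered ring containing sulfur for a six-membered carbon ring carrying a nitro group, with 9 heavy atoms entering where 5 leave, produces no difference that can be told from the usual scatter. Going by these compounds alone, the earlier compounds offered no single-place step that exchanged one aromatic ring for another, so this is the first direct reading of such a change at this position. No measurement is available to explain this result.

On these data alone, whether this position would behave the same with a group that is not an aromatic ring, such as a short alkyl chain or a carboxylic acid, remains open. A 3-aminophenyl group here would show whether the nitro group itself can be exchanged with as little effect on this read-out.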